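Two Aryl Triazole Amides Below the Assay Ceiling

This account rests on a few compounds, and the source may have more. Where it says the series, first, only, none or still open, it means among the compounds named here.

Compound 1 `CCc1ccccc1-n1nncc1CN1C(=O)C2(C(C#N)=C(N)Oc3c(N)cc4nc5ccccc5nc4c32)c2ccccc21` gives > 50000 nM in an ADME assay on HUVEC cells (Homo sapiens) for antiproliferative activity, read by MTT assay, with a stated time of 48 h (a lower number here means a stronger inhibitor, a higher number a weaker inhibitor), which is a limit of the assay rather than a number.
Compound 2 `CCc1cccc(C)c1-n1nncc1CN1C(=O)C2(C(C#N)=C(N)Oc3c(N)cc4nc5ccccc5nc4c32)c2ccccc21` gives > 50000 nM in this assay, again a limit and not a number.

Among the compounds with values here, compound 2 therefore stands at the ceiling of what this assay can report, and the one further value shown, that of compound 1, is a limit as well. Within the data shown here, the only measured step, a step that the two limits leave unreadable from compound 1 to compound 2, places methyl in place of hydrogen on an aromatic carbon, yet its size cannot be read because both ends sit at the same limit (the limit of > 50000 nM in this assay, at which 2 of the 2 values shown sit).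

Compound 3 `Cc1cc(C)c(-n2nncc2CN2C(=O)C3(C(C#N)=C(N)Oc4c(N)cc5nc6ccccc6nc5c43)c3ccccc32)c(C)c1` differs from compound 2 by 2,4,6-trimethylphenyl in place of 2-ethyl-6-methylphenyl on an aromatic nitrogen. This change keeps the same atoms joined differently on the group attached to the aromatic nitrogen of the five-membered ring. Among the measured compounds shown here, no measured step shows the effect of such a rearrangement, and the one step available, that from compound 1 to compound 2, gives no readable size. There is thus no ground to expect a step beyond the scatter in this assay in either direction.

Compound 3 is accordingly expected to give 60000 nM, with a range from 20000 nM to 200000 nM, most likely reported again only as a limit, so the expected step that the limit leaves unreadable from compound 2 to compound 3 is essentially none.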

Compound 3, half-maximal inhibitory concentration: > 50000 nM
Compound 3: a limit, no number; the forecaster's own chance of this, stated with the estimate: 85%; the middle value is on the limit's open side.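

The steps from compound 1 and from compound 2 to compound 3 cannot be read, because all three compounds sit at one and the same limit: the limit of > 50000 nM in this assay, at which 3 of the 3 values shown sit. The compounds shown leave open how strongly any of them acts in this assay, and whether changing the group on the aromatic nitrogen alters that activity at all.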